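Amide to Urea on a Shared Pyrazole-Free Core Name

The source may hold more compounds than are shown below. What is called first, only, known or untested is meant among the compounds shown, and "the series" means these compounds.

Measured compounds:
compound 1 `COc1cc(-c2nn(-c3cccc(NC(=O)c4ccc(Cl)c(C(F)(F)F)c4)c3)cc2-c2ccncc2)ccc1Cl`, a limit of > 32500 nM
compound 2 `COc1cc(-c2nn(-c3cccc(NC(=O)c4cccc(C(F)(F)F)c4)c3)cc2-c2ccncc2)ccc1Cl`, a limit of > 50000 nM
compound 3 `O=C(Nc1cccc(-n2cc(-c3ccncc3)c(-c3ccc(Cl)c(O)c3)n2)c1)Nc1ccc(Cl)c(C(F)(F)F)c1`, a limit of > 32500 nM

In a functional assay on T47D cells (Homo sapiens) for inhibition, read by sulforhodamine B assay, with a stated time of 48 h (on this read-out higher numbers stand for lower toxicity in this test and lower numbers for higher toxicity in this test), compound 1 gives only a limit, > 32500 nM. Compound 2 likewise reaches only a limit, > 50000 nM. Compound 3 too stops at a limit, > 32500 nM. Thus the one measured step, a step that the two limits leave unreadable from compound 1 to compound 2, cannot be read, and compound 1 stands at the limit of > 32500 nM in this assay, at which 2 of the 3 values shown sit, with no number of its own.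

Compound 4 `COc1cc(-c2nn(-c3cccc(NC(=O)Nc4ccc(Cl)c(Cl)c4)c3)cc2-c2ccncc2)ccc1Cl` differs from compound 1 in one place: (3,4-dichlorophenyl)amino in place of 4-chloro-3-(trifluoromethyl)phenyl on a carbonyl carbon. Among the compounds with values here, no measured step covers this change; compound 3, which also carries a urea, gives only a limit. Compound 4 is therefore expected to stay unreadable as well, with an estimated 40000 nM ranging from 10000 nM to 120000 nM. The expected step that the limit leaves unreadable from compound 1 to compound 4 is judged to lie within the scatter.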

Compound 4, concentration lethal to 50% of the cells: > 50000 nM
Compound 4: no number, only a limit; the forecaster's own chance of this, stated with the estimate: 85%; middle value at least 1.2-fold (0.09 log units) away from the limit.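

Compound 4, like compound 1 and compound 2, gives only a limit in this assay, so the steps from either of them to compound 4 cannot be read. No compound shown gives an actual number, which leaves open whether swapping amide for urea changes toxicity at all.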